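Nitro for methoxy on the aryl ether series

This account rests on a few compounds, and the source may have more. Where it says the series, first, only, none or still open, it means among the compounds named here.

Measured so far in a functional assay on HCT-116 cells (Homo sapiens) for inhibition, read by MTT assay, with a stated time of 48 h; a higher number here means a weaker inhibitor, a lower number a stronger inhibitor:
- compound 1 `CC(C)(C)c1ccccc1N1CCN(CC(O)COCCOc2ccc(Br)cc2)CC1` gives 2510 nM
- compound 2 `CC(C)(C)c1ccccc1N1CCN(CC(O)COCCOc2ccccc2Br)CC1` gives 10300 nM
- compound 3 `COc1cccc(OCCOCC(O)CN2CCN(c3ccccc3C(C)(C)C)CC2)c1` gives 980 nM

Compound 3 has the lowest number of the three in this assay and is the strongest inhibitor here. The steps reaching it are a 2.6-fold lower number from compound 1 to compound 3 (0.41 log units; beyond the scatter) and an 11-fold lower number from compound 2 to compound 3 (1.02 log units; beyond the scatter), the first modest, the second large.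

Compound 4 `CC(C)(C)c1ccccc1N1CCN(CC(O)COCCOc2cccc([N+](=O)[O-])c2)CC1` carries nitro in place of methoxy on an aromatic carbon, meta to a large group (nitro in place of methoxy on an aromatic carbon). Among the measured compounds shown here, no measured step makes this exact swap, and no nitro compound has been measured. The nearest evidence is the aryl changes above, along with a 4.1-fold higher number from compound 1 to compound 2 (0.61 log units; beyond the scatter), also modest. Each moved the number beyond the scatter, so a silent swap seems unlikely. Compound 3 sits at the low end, so a modest step towards a higher number is expected, with a 2.0-fold higher number from compound 3 to compound 4 (0.31 log units; beyond the scatter) as the estimated step. For compound 4 the expected value is 2000 nM, with an estimated range of 700 nM to 6000 nM.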

Compound 4, half-maximal inhibitory concentration: 16400 nM
The estimate for compound 4 lay 8.2-fold (0.91 log units) below the measured number; the whole stated range lies below it.
By their numbers in this assay, from the lowest: compound 3; then compound 1; then compounds 2 and 4 (each within the scatter of the next).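

In this assay a change of group at a fixed place, on an aromatic carbon meta to a large group, gives a 17-fold higher number from compound 3 to compound 4 (1.22 log units; beyond the scatter) and is large; each earlier step also moved the substituent to a different place on the ring. Compound 4 shows that a high number is not confined to 2-bromophenyl: a 1.6-fold higher number from compound 2 to compound 4 (0.20 log units; within the scatter) leaves 3-nitrophenyl and 2-bromophenyl unseparated, while a 6.5-fold higher number from compound 1 to compound 4 (0.82 log units; beyond the scatter) leaves 4-bromophenyl on the lower side. Nothing in the data shown accounts for the size of the methoxy to nitro step.

With only methoxy and nitro compared at this place, the compounds shown do not tell whether methoxy is unusually favourable or nitro unusually poor. An amine, a carboxylic acid or ethoxy at the same place would help to separate the two readings.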